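This account rests on a few compounds, and the source may have more. Where it says the series, first, only, none or still open, it means among the compounds named here.

In an ADME assay on liver (Mus musculus) for metabolic stability, read by LC-MS, using microsomes and NADPH (on this read-out lower numbers stand for a less stable compound and higher numbers for a more stable compound), three compounds that share a core and differ in one place have been measured. Compound 1 `CCN(Cc1ccc(OCCN2C(=O)CCC2=O)c(C)c1)C(CC(=O)O)c1ccc(Cl)cc1` reads 88% and compound 2 `Cc1cc(CN(CC2CC2)C(CC(=O)O)c2ccc(Cl)cc2)ccc1OCCN1C(=O)CCC1=O` reads 83% while compound 3 `CCCCN(Cc1ccc(OCCN2C(=O)CCC2=O)c(C)c1)C(CC(=O)O)c1ccc(Cl)cc1` reads 88% and so stands within the scatter of both others. Compound 4 `Cc1cc(CN(CC2CCCC2)C(CC(=O)O)c2ccc(Cl)cc2)ccc1OCCN1C(=O)CCC1=O` has not yet been measured and departs from compound 3 by a single change (cyclopentyl in place of propyl on a saturated chain carbon bound to an amine nitrogen) that puts cyclopentyl in place of propyl on a saturated chain carbon bound to an amine nitrogen. The closest measured comparison swaps cyclopropyl for propyl at that same place and gives a number 5 percentage points higher from compound 2 to compound 3 (within the scatter) as its result. The other two measured steps are a number 5 percentage points lower from compound 1 to compound 2 (within the scatter) and no change at the digits printed from compound 1 to compound 3 (within the scatter) and neither leaves the scatter. Within the data shown here, no measured compound carries cyclopentyl, so any forecast here is an extrapolation. The only ring measured at this place sits in compound 2 at 83% and this supports no more than a slight expected lean downward. The step expected for compound 4 is a number 6 percentage points lower from compound 3 to compound 4 (within the scatter) and so none beyond the scatter. For compound 4 the estimated value is 82% with 68% to 93% as the expected range.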

Compound 4, percent of the compound remaining: 52%
Beside the measured number, compound 4's estimate is 30 percentage points above it; the measured number lies below the stated range.
By their numbers in this assay, from the lowest: compound 4; then compounds 2, 1 and 3 (each within the scatter of the next).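

In this assay, the three earlier compounds stayed within the scatter of one another, so this place on a saturated chain carbon bound to an amine nitrogen looked tolerant of change. Cyclopentyl shows that this tolerance has a limit: replacing propyl gives a large loss (a number 36 percentage points lower from compound 3 to compound 4 (beyond the scatter)), replacing cyclopropyl gives a similar one (a number 31 percentage points lower from compound 2 to compound 4 (beyond the scatter)), and replacing the methyl of the shorter ethyl chain does the same (a number 36 percentage points lower from compound 1 to compound 4 (beyond the scatter)). A ring alone does not go with the loss, as compound 2 also carries a ring at this place and remains within the scatter of the open-chain compound 1 and compound 3, so the sharp fall belongs to cyclopentyl among the groups shown.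

Nothing available explains why stability drops so sharply with this one group. As far as these compounds go, it also remains open whether cyclobutyl, the ring size between cyclopropyl and cyclopentyl, would read like compound 2 or like compound 4, and whether cyclohexyl or an open pentyl chain would show the same loss.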